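Removing the Nitro Group: What to Expect for Compound 3

The compounds below may be only part of what the source reports. "The series", "measured", "known", "first", "only" and "open" are said of these compounds alone.

Of the compounds shown here, two have been measured in a functional assay, read by spectrophotometry, with a stated time of 20 min; on this read-out lower numbers stand for stronger inhibition and higher numbers for weaker inhibition. Compound 1 `CC(=O)c1ccc(NC(=O)CN(C(=O)c2ccccc2)S(=O)(=O)c2ccc(C)cc2)cc1` gives 102000000 nM in this assay. Compound 2 `CC(=O)c1ccc(NC(=O)CN(C(=O)c2ccccc2)S(=O)(=O)c2ccc([N+](=O)[O-])cc2)cc1` gives 58000000 nM in this assay. Within the data shown here, these are the only two numbers so far, joined by the single measured step of a 1.8-fold lower number from compound 1 to compound 2 (0.25 log units; within the scatter), so compound 2 stands within the scatter of compound 1 rather than apart from it.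

Compound 3 `CC(=O)c1ccc(NC(=O)CN(C(=O)c2ccccc2)S(=O)(=O)c2ccccc2)cc1` has not yet been measured. It differs from compound 2 by hydrogen in place of nitro on an aromatic carbon, which read one bond further out is 4-nitrophenyl to phenyl. Among the measured compounds shown here, the only measured step that bears on this aromatic carbon is a 1.8-fold lower number from compound 1 to compound 2 (0.25 log units; within the scatter), where methyl gave way to nitro. Compound 3 now puts hydrogen where that nitro sat, with nothing else altered. For the measured compounds named here, because the one comparable step a 1.8-fold lower number from compound 1 to compound 2 (0.25 log units; within the scatter) stayed within the scatter, no step beyond the scatter is expected in this assay in either direction. The expected step is a 1.4-fold higher number from compound 2 to compound 3 (0.14 log units; within the scatter). Compound 3 is therefore estimated at 80000000 nM, with a range from 30000000 nM to 200000000 nM.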

Compound 3, half-maximal inhibitory concentration: 32000000 nM
Compound 3: middle estimate off by 2.5-fold (0.40 log units), on the high side, within the range that was stated.
By their numbers in this assay, from the lowest: compounds 3, 2 and 1 (each within the scatter of the next, the first and the last beyond it).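

In this assay, among these compounds, replacing methyl with hydrogen on this aromatic carbon gives a 3.2-fold lower number from compound 1 to compound 3 (0.50 log units; beyond the scatter), the first step at this position to lie beyond the scatter, though it is only modest. Replacing nitro with hydrogen gives a 1.8-fold lower number from compound 2 to compound 3 (0.26 log units; within the scatter) and, like the earlier step of a 1.8-fold lower number from compound 1 to compound 2 (0.25 log units; within the scatter), stays within the scatter, so nitro cannot be separated from either neighbour in the series even though hydrogen and methyl stand apart, with the lower number belonging to hydrogen. No supporting evidence bears on why the group at this position shifts the number in this way.

As far as these compounds go, whether an amine or a carboxylic acid on this aromatic carbon would fall with hydrogen, with methyl or outside the span of these three compounds remains open. All three compounds differ only at this one place, so they also leave open how changes elsewhere on the shared core would behave, and whether the modest separation between hydrogen and methyl would hold there.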